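Swapping a Saturated Side Chain for an Unsaturated One

The source may report more compounds than this note shows. Statements on the series, on what has been measured and on what is new or still open speak of the compounds shown alone.

Compound 1 `COc1cc(Cc2nc3c(N)ncnc3n2CC(C)C)cc(OC)c1OC` is a small molecule tested in a functional assay on MCF7 cells (Homo sapiens) for antiproliferative activity (on this read-out lower numbers stand for stronger inhibition and higher numbers for weaker inhibition), where compound 1 gives 97700 nM. For the measured compounds named here, only one other measured compound is at hand: compound 2 `COc1cc(Cc2nc3c(N)nc(F)nc3n2CCOC(C)C)c(Cl)c(OC)c1OC`, which in this assay gives 5370 nM. Compound 1 therefore stands as the higher of the two numbers, and the gap to compound 2 lies beyond the usual scatter; since the two structures differ in several places at once, the gap cannot be tied to any single change.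

Compound 3 `C/C=C/Cn1c(Cc2cc(OC)c(OC)c(OC)c2)nc2c(N)ncnc21` has not been measured. Relative to compound 1 it carries one change, (prop-1-en-1-yl in place of isopropyl on a saturated chain carbon bound to an aromatic nitrogen), on a saturated chain carbon bound to an aromatic nitrogen, with no change in hydrogen-bond donors or acceptors or in charge. Going by the values given here, no measured pair shows what such an exchange does here, so the expectation rests on the small size of the change alone.

The step from compound 1 to compound 3 in this assay is expected to be a 1.2-fold lower number from compound 1 to compound 3 (0.09 log units; within the scatter), that is, none beyond the scatter. Compound 3 is accordingly estimated at 80000 nM, within a range from 30000 nM to 250000 nM.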

Compound 3, half-maximal inhibitory concentration: 51300 nM
Estimate against measurement, compound 3: 1.6-fold (0.19 log units) above, within the range that was stated.
By their numbers in this assay, from the lowest: compound 2; then compounds 3 and 1 (each within the scatter of the next).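

In this assay, for the compounds shown here, the exchange of prop-1-en-1-yl for isopropyl, on a saturated chain carbon bound to an aromatic nitrogen, gives a 1.9-fold lower number from compound 1 to compound 3 (0.28 log units; within the scatter) and is the first measured change at this position that stands alone. A double bond outside aromatic rings can therefore enter this side chain, with the same number of heavy atoms and no added hydrogen-bond donor or acceptor, while the two numbers remain indistinguishable in this assay, so in this one pair, saturation of the chain does not set the result apart. No measured property of either side chain is available to help interpret this outcome.

Going by these compounds alone, this single pair tests only one kind of exchange, so it remains open whether a longer chain, an amine or a carboxylic acid at this place would move the number beyond the scatter. Compound 2 differs from both compound 1 and compound 3 in several places at once, which leaves open how much, if any, of its separate value belongs to its side chain.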